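The source may report more compounds than this note shows. Statements on the series, on what has been measured and on what is new or still open speak of the compounds shown alone.

Measured compounds in an assay on isolated protein (spleen) for agonist activity at Alpha-1B adrenergic receptor (Rattus norvegicus); a lower number here means that less compound is needed, a higher number that more compound is needed for the effect:
- compound 1 `CS(=O)(=O)Nc1c(O)ccc2c1CCCC2c1c[nH]cn1`: 229 nM
- compound 2 `CCS(=O)(=O)Nc1cccc2c1CCC[C@H]2c1c[nH]cn1`: 3800 nM
- compound 3 `CC(C)S(=O)(=O)Nc1cccc2c1CCCC2c1c[nH]cn1`: 14100 nM

Compound 3 gives the highest number of the three in this assay. Compound 2 sits nearest to it, yet the gap between compound 2 and compound 3 is beyond the usual scatter; compound 1 lies furthest away, also well beyond the scatter. Across these three the numbers rise as the sulfonyl group on the ring nitrogen grows from methylsulfonyl through ethylsulfonyl to isopropylsulfonyl, though compound 1 also carries a hydroxy group that compound 2 and compound 3 lack, so the comparison with compound 1 is not clean.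

Compound 4 `Nc1cccc2c1CCCC2c1c[nH]cn1` has not been measured. It differs from compound 3 by hydrogen in place of isopropylsulfonyl on a nitrogen on an aromatic ring. Within the data shown here, no measured pair shows this change, so the expectation rests on the direction seen from compound 2 and compound 3: removing the whole sulfonyl group is expected to lower the number, a step of moderate size beyond the scatter, with wide uncertainty since the free amine stands outside the measured range. The expected step from compound 3 to compound 4 is a 4.7-fold lower number from compound 3 to compound 4 (0.67 log units; beyond the scatter). Compound 4 is estimated at 3000 nM, within a range of 500 nM to 20000 nM.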

Compound 4, half-maximal effective concentration: 977 nM
For compound 4 the middle estimate is 3.1-fold (0.49 log units) above the measured one, within the range that was stated.
By their numbers in this assay, from the lowest: compound 1; then compound 4; then compound 2; then compound 3.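

In this assay, among these compounds, replacing isopropylsulfonyl with hydrogen on the nitrogen on the aromatic ring gives a 14-fold lower number from compound 3 to compound 4 (1.16 log units; beyond the scatter), the first step read between two compounds that differ in one place. Among the compounds shown here, at this position the sulfonyl group is therefore not required for a response in this assay: compound 4, with a plain amino group, gives 977 nM, and on this core the isopropylsulfonyl compound is the one with the higher number. Nothing available bears on the reason for this step.

From the compounds shown here alone, it remains open whether other groups on the same nitrogen, such as acetyl, methyl or a longer alkyl chain, would stay close to compound 4 or move towards compound 3, and whether an unbranched sulfonyl group would give a smaller step than isopropylsulfonyl when compared on an otherwise identical compound. Also unresolved are the effect of adding the hydroxy group of compound 1 to the core of compound 4 and the separate contribution of each mirror-image form of compound 4.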